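Swapping the aryl group beside the acrylamide-bearing core

The source may hold more compounds than are shown below. What is called first, only, known or untested is meant among the compounds shown, and "the series" means these compounds.

Measured compounds:
compound 1, `C=C(Br)C(=O)Nc1cccc(-c2cn3nc(Cc4cccc(OC)c4)sc3n2)c1`, 2000 nM
compound 2, `COc1ccc(-c2nn3cc(-c4cccc(N)c4)nc3s2)cc1`, >= 250000 nM
compound 3, `C=C(Br)C(=O)Nc1cccc(-c2cn3nc(-c4cccs4)sc3n2)c1`, 170 nM

In a functional assay on L1210 cells (Mus musculus) for inhibition, read by cell counting, with a stated time of 2 days (a lower number here means a stronger inhibitor, a higher number a weaker inhibitor), compound 3 gives 170 nM, the lowest of the two numbers that are actual numbers. Within the data shown here, compound 1 is its nearest neighbour, and the step of a 12-fold lower number from compound 1 to compound 3 (1.07 log units; beyond the scatter) is the only measured step between compounds differing in one place. For compound 2 this assay gives only a limit, >= 250000 nM, and the limit of >= 250000 nM in this assay, at which 1 of the 3 values shown sits, marks where that limit sits; compound 2 also carries an amine in place of the acrylamide, so it does not stand one change away from compound 3.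

Compound 4 is `C=C(Br)C(=O)Nc1cccc(-c2cn3nc(-c4ccc(OC)cc4)sc3n2)c1`. The change from compound 3 is 4-methoxyphenyl in place of thiophen-2-yl on an aromatic carbon. Among the measured compounds shown here, no measured step covers exactly this swap; the one step that bears on it, the exchange of a methoxybenzyl for a thiophen-2-yl, was large in favour of compound 3. A ring attached directly, as in compound 4, sits structurally between the two, so the expected step of a 2.6-fold higher number from compound 3 to compound 4 (0.42 log units; beyond the scatter) points toward a somewhat higher number. Compound 4 is therefore estimated at 450 nM, with a range from 120 nM to 2500 nM.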

Compound 4, half-maximal inhibitory concentration: 940 nM
Estimate against measurement, compound 4: 2.1-fold (0.32 log units) below; the measured number falls inside the stated range.
By their numbers in this assay, from the lowest: compound 3; then compound 4; then compound 1. At a limit, above all of these: compound 2.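

In this assay, the thiophen-2-yl keeps its lead over the 4-methoxyphenyl at this position, with a 5.5-fold higher number from compound 3 to compound 4 (0.74 log units; beyond the scatter), while the 4-methoxyphenyl in turn improves on the 3-methoxybenzyl, with a 2.1-fold lower number from compound 1 to compound 4 (0.33 log units; beyond the scatter), so the three groups now form a ranked series. Compound 4 also gives the first one-change view of the (1-bromoethenyl)carbonyl group on the nitrogen, with an at least 260-fold lower number from compound 2 to compound 4 (2.42 log units; beyond the scatter), a large step in favour of carrying that group. The value of compound 2 behind this step is a limit of the assay and not a number: the limit of >= 250000 nM in this assay, at which 1 of the 4 values shown sits.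

The compounds shown leave open how a plain phenyl, a thiophen-3-yl or a pyridine ring would compare with the thiophen-2-yl at this position. They also leave open how an unbrominated acrylamide or a chloroacetamide would compare on that nitrogen.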